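This account rests on a few compounds, and the source may have more. Where it says the series, first, only, none or still open, it means among the compounds named here.

Measured so far:
compound 1 `O=S(=O)(NCCCNc1nccc(-c2c(-c3cccc(F)c3)nc3sccn23)n1)c1ccc(F)cc1` — 14500 nM in a functional assay on A-375 cells (Homo sapiens) for cytotoxicity, read by MTT assay; a lower number here means a stronger inhibitor, a higher number a weaker inhibitor
compound 2 `O=S(=O)(NCCCNc1nccc(-c2c(-c3cccc(F)c3)nc3sccn23)n1)c1ccc(Cl)cc1` — 5900 nM in this assay

Going by the values given here, compound 2 stands at the lowest of the two numbers in this assay; its nearest neighbour is compound 1, which gives 14500 nM, and the step of a 2.5-fold lower number from compound 1 to compound 2 (0.39 log units; beyond the scatter) is the only measured step in this set.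

Compound 3 `O=S(=O)(NCCCNc1nccc(-c2c(-c3cccc(F)c3)nc3sccn23)n1)c1ccccc1` is the next compound to be measured in this assay. Compared with compound 2 it differs as follows: hydrogen in place of chloro on an aromatic carbon.

Among the compounds with values here, the one measured step that bears on this change is a 2.5-fold lower number from compound 1 to compound 2 (0.39 log units; beyond the scatter), which concerns the same aromatic carbon and shows that exchanging the halogen there moved the number by a modest amount. Removing the chloro altogether is a step of the same kind, and the expectation is that the number in this assay will rise again, by roughly a modest margin in the opposite direction, since compound 2 is the better of the two measured compounds because of a 2.5-fold lower number from compound 1 to compound 2 (0.39 log units; beyond the scatter).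

Compound 3 is therefore expected to give about 12000 nM in this assay, within a range of 5000 nM to 30000 nM, which means an estimated step of a 2.0-fold higher number from compound 2 to compound 3 (0.31 log units; beyond the scatter).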

Compound 3, half-maximal inhibitory concentration: 6600 nM
The estimate for compound 3 lay 1.8-fold (0.26 log units) above the measured number; measured number inside the range.
By their numbers in this assay, from the lowest: compounds 2 and 3 (each within the scatter of the next); then compound 1.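

In this assay, hydrogen in place of chloro on the aromatic carbon gives a 1.1-fold higher number from compound 2 to compound 3 (0.05 log units; within the scatter), so the chloro of the 4-chlorophenyl group can be removed with no change beyond the scatter, and the phenylsulfonyl and (4-chlorophenyl)sulfonyl forms cannot be told apart by this read-out. Hydrogen in place of fluoro at the same carbon gives a 2.2-fold lower number from compound 1 to compound 3 (0.34 log units; beyond the scatter), which changes how the earlier halogen exchange reads: among these three compounds it is the fluoro form that stands apart with the higher number, while chloro offers no measurable gain over hydrogen. No evidence on the cause of this pattern is available.

The three compounds leave open whether any other group at this carbon, such as a methyl, a methoxy, a trifluoromethyl, a nitrile or an amine, would move the number beyond the scatter in either direction. They also leave open whether the same order of fluoro, chloro and hydrogen would hold with a longer chain or with a chloro or fluoro placed elsewhere on the ring.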